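A few compounds are considered here, and "the series" means these few. Any claim that something is new, unique, unknown or untested is made for them only; others in the source may bear on it.

Measured so far in a physicochemical assay for solubility, read by LC-MS, in phosphate buffer, measured as thermodynamic solubility, with a stated time of 24 h, at pH 7.4; a higher number here means a more soluble compound, a lower number a less soluble compound:
compound 1 `Cn1cc(-c2cnc3[nH]cc(-c4cc(F)cc(C#N)c4)c3c2)cn1`, 500 nM;
compound 2 `Cn1cc(-c2cnc3[nH]cc(-c4ccncc4)c3c2)cn1`, 59000 nM;
compound 3 `N#Cc1cccc(-c2c[nH]c3ncc(-c4cn[nH]c4)cc23)c1`, 26000 nM.

Compound 3 stands second highest of these three numbers. Its nearest neighbour is compound 2, whose number is higher by a gap beyond the scatter; compound 1 lies far lower, also beyond the scatter. Compound 4 `N#Cc1cccc(-c2c[nH]c3ncc(N4CCNCC4)cc23)c1` has not yet been measured in this assay. It differs from compound 3 in one place: piperazin-1-yl in place of 1H-pyrazol-4-yl on an aromatic carbon. Going by the values given here, no pair of measured compounds here differs in a single place, so no measured step guides this change directly. Still, a step upward beyond the scatter is expected, of moderate size. The expected step is a 2.7-fold higher number from compound 3 to compound 4 (0.43 log units; beyond the scatter). Compound 4 is estimated at 70000 nM, with a range from 18000 nM to 280000 nM.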

Compound 4, solubility: 240000 nM
Estimate against measurement, compound 4: 3.4-fold (0.54 log units) below, and the stated range covers the measured number.
By their numbers in this assay, from the lowest: compound 1; then compound 3; then compound 2; then compound 4.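

In this assay, putting piperazin-1-yl in place of 1H-pyrazol-4-yl on this aromatic carbon gives a 9.2-fold higher number from compound 3 to compound 4 (0.97 log units; beyond the scatter), the first single-place step available in this series. It shows that this position, two atoms from the ring nitrogen, can carry a six-membered non-aromatic ring in place of a five-membered aromatic one, with the number moving upward. Nothing shown here gives a reason for this rise. Still open, on these data alone, is whether the non-aromatic ring itself matters or its ring nitrogen does. Morpholin-4-yl or an open-chain amine such as dimethylamino on the same carbon would bear on that question.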